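The source may report more compounds than this note shows. Statements on the series, on what has been measured and on what is new or still open speak of the compounds shown alone.

In a functional assay (aorta) with Rattus norvegicus as the target (a higher number here means a weaker inhibitor, a lower number a stronger inhibitor), compound 1 (`CCCCCN(CCCCC)CCCOc1ccc(S(=O)(=O)c2c(C(C)C)cn3ccccc23)cc1`) gives 89.6 nM, while compound 2 (`COc1ccc(CN(C)CCCOc2ccc(S(=O)(=O)c3c(C(C)C)cn4ccccc34)cc2)cc1OC`) gives 3.18 nM, the lower of the two numbers and a gap from compound 1 well beyond the scatter. Compound 3 (`COc1ccc(CNCCCOc2ccc(S(=O)(=O)c3c(C(C)C)cn4ccccc34)cc2)cc1OC`) has hydrogen in place of methyl on an amine nitrogen of compound 2: hydrogen in place of methyl on an amine nitrogen. Among the compounds with values here, no measured pair in this assay isolates this change, so the expectation is tentative. A modest rise towards a weaker inhibitor is expected, estimated as a 2.5-fold higher number from compound 2 to compound 3 (0.40 log units; beyond the scatter). In this assay the estimated value for compound 3 is 8 nM, with an expected range of 1.5 nM to 40 nM.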

Compound 3, half-maximal inhibitory concentration: 13 nM
Estimate against measurement, compound 3: 1.6-fold (0.21 log units) below, within the range that was stated.
By their numbers in this assay, from the lowest: compound 2; then compound 3; then compound 1.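

With hydrogen in place of methyl on the amine nitrogen, this assay shows a 4.1-fold higher number from compound 2 to compound 3 (0.61 log units; beyond the scatter), so this nitrogen is sensitive to even a single-carbon change. Without that methyl, the (3,4-dimethoxybenzyl)amino group still compares well with dipentylamino, giving a 6.9-fold lower number from compound 1 to compound 3 (0.84 log units; beyond the scatter), so the advantage over compound 1 does not depend on the methyl alone. Nothing available explains either step. Still open, going by these compounds, is how an ethyl group or a longer chain on this nitrogen would compare with methyl. Also open, on these data alone, is what a plain benzyl group would give without the two methoxy groups.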